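Cytotoxicity series: varying the aryl on the lactam nitrogen

A few compounds are considered here, and "the series" means these few. Any claim that something is new, unique, unknown or untested is made for them only; others in the source may bear on it.

Measured so far in a functional assay on HEK293 cells (Homo sapiens) for cytotoxicity; on this read-out higher numbers stand for lower toxicity in this test and lower numbers for higher toxicity in this test:
- compound 1 `COc1ccc([C@H]2CC(=O)N(c3cc(N)cc(N)c3)C2)cc1OC1CCCC1`: > 10000 nM (a limit of the assay, not a number)
- compound 2 `COc1ccc([C@H]2CC(=O)N(c3ccc(N)cc3)C2)cc1OC1CCCC1`: > 10000 nM (a limit of the assay)
- compound 3 `COc1ccc([C@H]2CC(=O)N(c3ccccc3C#N)C2)cc1OC1CCCC1`: > 10000 nM (a limit of the assay)

Compound 1 stands only at a limit in this assay; the two other values shown are limits as well, so no ranking among the three is readable. Among the measured compounds shown here, the steps a step that the two limits leave unreadable from compound 1 to compound 2, a step that the two limits leave unreadable from compound 1 to compound 3 and a step that the two limits leave unreadable from compound 2 to compound 3 are accordingly unreadable in size, and the only evidence on them is the limit of > 10000 nM in this assay, at which 3 of the 3 values shown sit.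

Compound 4 `COc1ccc([C@H]2CC(=O)N(c3ccc(C)cc3)C2)cc1OC1CCCC1` has not yet been measured in this assay. Against compound 1 it differs as follows: 4-methylphenyl in place of 3,5-diaminophenyl on an amide-type nitrogen in a ring.

For the measured compounds named here, none of the measured steps gives a readable size, so no direction can be drawn from them; they show only that three different aryl groups on the amide-type nitrogen all stay at the limit. Compound 4 is therefore expected to stay at that limit too, with the step from compound 1 estimated as a step that the limit leaves unreadable from compound 1 to compound 4, that is, none beyond the scatter. The estimate for compound 4 in this assay is 15000 nM, with a range from 8000 nM to 40000 nM, and most likely the assay will again report only a limit.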

Compound 4, half-maximal cytotoxic concentration: > 10000 nM
Compound 4: no number, only a limit (the forecaster's own chance of this, stated with the estimate: 80%); the middle value is on the limit's open side.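

In this assay compound 4 gives > 10000 nM, a limit of the assay and not a number. Its steps from compound 1, compound 2 and compound 3 cannot be read in size: the limit of > 10000 nM in this assay, at which 4 of the 4 values shown sit. The compounds shown leave open whether any aryl group on the amide-type nitrogen gives a readable value in this assay, and so how these groups rank.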